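Trimethoxyphenyl pyrazolyl chalcones: demethoxylation steps

The source may report more compounds than this note shows. Statements on the series, on what has been measured and on what is new or still open speak of the compounds shown alone.

Of the compounds shown here, three have been measured in a functional assay on KM12 cells (Homo sapiens) for inhibition, read by sulforhodamine B assay, with a stated time of 48 h; on this read-out higher numbers stand for lower toxicity in this test and lower numbers for higher toxicity in this test. Compound 1 `COc1cc(-c2cc(/C=C/C(=O)c3ccc(N)cc3)[nH]n2)cc(OC)c1OC` gives 7270 nM, and compound 2 `COc1ccc(-c2cc(/C=C/C(=O)c3ccc(N)cc3)[nH]n2)cc1OC` gives 6670 nM. The change between them is hydrogen in place of methoxy on an aromatic carbon, and it made the step of a 1.1-fold lower number from compound 1 to compound 2 (0.04 log units; within the scatter). Compound 3 `COc1cc(C(=O)/C=C/c2cc(-c3cc(OC)c(OC)c(OC)c3)n[nH]2)cc(OC)c1OC` has a different core, and its difference from compound 1 is not broken down here. In this assay compound 3 gives 5770 nM; its gap to compound 2 and to compound 1 is within the scatter, so no order among the three can be read from these numbers.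

Compound 4 `COc1ccc(-c2cc(/C=C/C(=O)c3cc(OC)c(OC)c(OC)c3)[nH]n2)cc1OC` is not yet measured. It differs from compound 3 by hydrogen in place of methoxy on an aromatic carbon, the same kind of change as that from compound 1 to compound 2, at a place described in the same words. The step expected here is a 1.1-fold lower number from compound 3 to compound 4 (0.04 log units; within the scatter), because the same change gave a 1.1-fold lower number from compound 1 to compound 2 (0.04 log units; within the scatter). On that basis compound 4 is expected to give about 5300 nM, estimated to lie between 2500 nM and 12000 nM.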

Compound 4, concentration lethal to 50% of the cells: 5680 nM
The estimate for compound 4 lay 1.1-fold (0.03 log units) below the measured number, within the range that was stated.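

In this assay, hydrogen in place of methoxy on an aromatic carbon gave a 1.0-fold lower number from compound 3 to compound 4 (0.01 log units; within the scatter) and so left the number where it stood on this core as well. The two cores do not differ in how they take this change: the same change on two cores in this assay, a 1.1-fold lower number (0.04 log units; within the scatter) from compound 1 to compound 2 and a 1.0-fold lower number (0.01 log units; within the scatter) from compound 3 to compound 4, 1.1-fold (0.03 log units) apart, within the scatter of two such steps. What carries over is therefore a step lost in the scatter on both the core of compound 1 and the core of compound 3, which shows that removing this methoxy did not produce a readable shift on either core, but does not show that the same would hold on any further core or at another aromatic carbon.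

Still open, going by these compounds, is whether anything other than hydrogen at this aromatic carbon would move the number, for instance a hydroxyl, a fluorine atom, a carboxylic acid or a longer chain such as ethoxy. Among the compounds shown here, also open is whether removing more than one methoxy group from the same ring would stay as flat as the single change did.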